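Swapping the Piperazine Substituent in a Thiocarbamate Series

A few compounds are considered here, and "the series" means these few. Any claim that something is new, unique, unknown or untested is made for them only; others in the source may bear on it.

Measured compounds:
compound 1 `Nc1ccccc1NC(=O)c1ccc(CSC(=S)N2CCN(Cc3ccncc3)CC2)cc1` — 18.4%
compound 2 `Nc1ccccc1NC(=O)c1ccc(CSC(=S)N2CCN(c3ccncc3)CC2)cc1` — 64.8%

Going by the values given here, in a functional assay on MGC-803 cells (Homo sapiens) for antiproliferative activity, read by CCK-8 assay, with a stated time of 72 h, tested at 2 uM (on this read-out lower numbers stand for a weaker effect and higher numbers for a stronger effect at the one concentration tested), compound 2 gives 64.8% and stands highest of the two numbers so far; its nearest neighbour, compound 1, gives 18.4%. Among the compounds with values here, the only measured step is a number 46.4 percentage points higher from compound 1 to compound 2 (beyond the scatter), which shows that the group on the ring nitrogen matters strongly here.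

Compound 3 `Nc1ccccc1NC(=O)c1ccc(CSC(=S)N2CCN(C3CCCCC3)CC2)cc1` has not yet been measured. It differs from compound 2 by cyclohexyl in place of pyridin-4-yl on an amine nitrogen in a ring. The measured step concerned a change between pyridin-4-yl and (pyridin-4-yl)methyl on that same nitrogen, so it only shows that this position is sensitive; it does not tell the direction for a cyclohexyl group. A sizeable change in either direction in this assay is possible. Compound 3 is therefore expected to give 45%, within 20% to 70%, a step of a number 19.8 percentage points lower from compound 2 to compound 3 (beyond the scatter) being estimated.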

Compound 3, a percentage reported as inhibition, at one concentration (the size of the read-out at that concentration, not a potency): 16.9%
Compound 3: middle estimate off by 28.1 percentage points, on the high side, outside the stated range (below it).
By their numbers in this assay, from the lowest: compounds 3 and 1 (each within the scatter of the next); then compound 2.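

In this assay, cyclohexyl in place of pyridin-4-yl on the amine nitrogen in a ring gives a number 47.9 percentage points lower from compound 2 to compound 3 (beyond the scatter), so the size of the group alone does not decide the outcome: both groups are six-membered rings with 6 heavy atoms, and one is aromatic with a ring nitrogen while the other is carbon only. Cyclohexyl in place of (pyridin-4-yl)methyl gives a number 1.5 percentage points lower from compound 1 to compound 3 (within the scatter), so among these three compounds only compound 2, with pyridin-4-yl, stands apart. Nothing available here explains why this change has such a large effect.

The compounds shown leave open whether an aromatic ring alone is enough or its ring nitrogen is also needed, which phenyl on the same nitrogen would help to separate. They also leave open whether the place of that ring nitrogen counts, as pyridin-3-yl or pyridin-2-yl would show.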